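Swapping the Phenyl Ring for an Imidazole at the Amide

The compounds below may be only part of what the source reports. "The series", "measured", "known", "first", "only" and "open" are said of these compounds alone.

Compound 1, `COc1ccc(-c2cnc(NC(=O)c3ccccc3OC)n2C)cc1`, is tested in a toxicity assay on THP-1 cells (Homo sapiens) for inhibition (on this read-out lower numbers stand for higher toxicity in this test and higher numbers for lower toxicity in this test), and gives only a limit, > 100000 nM. Compound 2, `COc1ccc(-c2cnc(NC(=O)c3ccccc3)n2C)cc1`, likewise reaches only the limit of this assay, > 100000 nM. The step that the two limits leave unreadable from compound 1 to compound 2 cannot be read, since both values sit at the limit of > 100000 nM in this assay, at which 2 of the 2 values shown sit. Compound 3, `COc1ccc(-c2cnc(NC(=O)c3cnc[nH]3)n2C)cc1`, differs from compound 2 by 1H-imidazol-5-yl in place of phenyl on a carbonyl carbon. For the measured compounds named here, no measured step shows how such a change moves this assay, and compound 2 itself stands at the limit. Compound 3 is therefore expected near 100000 nM, within 30000 nM to 300000 nM. The step of a number no higher from compound 2 to compound 3 (the limit leaves the size open) is expected to stay within the scatter.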

Compound 3, half-maximal cytotoxic concentration: > 100000 nM
Compound 3 ended at the assay's limit; the forecaster's own chance of this, stated with the estimate: 80%; the middle value sits exactly at the limit.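

No step can be read among compound 1, compound 2 and compound 3, as each gives only a limit and not a number: the limit of > 100000 nM in this assay, at which 3 of the 3 values shown sit.

The compounds shown leave open whether changing the group on the carbonyl carbon affects toxicity in this assay at all.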